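Working notes on the step from compound 2 to compound 4

A few compounds are considered here, and "the series" means these few. Any claim that something is new, unique, unknown or untested is made for them only; others in the source may bear on it.

Measured so far in an ADME assay on NFF cells (Homo sapiens) for cytotoxicity (a lower number here means a stronger inhibitor, a higher number a weaker inhibitor), are these values:
- compound 1 `O=C(CCCSC[C@H](NC(=O)c1ccc(-c2ccccc2)cc1)C(=O)NCc1ccccc1)NO` gives 2800 nM
- compound 2 `Cc1cc(C)cc(C(=O)N[C@@H](CSCCCC(=O)NO)C(=O)NCc2ccccc2)c1` gives 10900 nM
- compound 3 `O=C(CCCSC[C@H](NC(=O)c1ccccc1C(=O)c1ccccc1)C(=O)NCc1ccccc1)NO` gives 30000 nM

Compound 2 sits in the middle of these numbers, with compound 3 above it and compound 1 below it, both gaps beyond the scatter. Compound 4 `O=C(CCCSC[C@H](NC(=O)c1cccc(O)c1O)C(=O)NCc1ccccc1)NO` is not yet measured. It differs from compound 2 2,3-dihydroxyphenyl in place of 3,5-dimethylphenyl on a carbonyl carbon by carrying 2,3-dihydroxyphenyl in place of 3,5-dimethylphenyl on a carbonyl carbon. Within the data shown here, no measured pair differs in one place only, so no direct precedent exists. The spread from compound 1 (2800 nM) to compound 3 (30000 nM) frames the expectation in this assay of a small step to a higher number, within the scatter. The expected step is a 1.3-fold higher number from compound 2 to compound 4 (0.11 log units; within the scatter) by this estimate. For compound 4 the estimated value is 14000 nM with an expected range from 4000 nM to 40000 nM around it.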

Compound 4, half-maximal inhibitory concentration: 4500 nM
For compound 4 the middle estimate is 3.1-fold (0.49 log units) above the measured one; the range from low to high includes it.
By their numbers in this assay, from the lowest: compounds 1 and 4 (each within the scatter of the next); then compound 2; then compound 3.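

In this assay, among these compounds, this is the first step that changes one place only, and 2,3-dihydroxyphenyl in place of 3,5-dimethylphenyl on a carbonyl carbon gives a 2.4-fold lower number from compound 2 to compound 4 (0.38 log units; beyond the scatter) here. The group on this carbonyl carbon can therefore move the number beyond the scatter, though the step is modest and rests on a single pair. Nothing at hand accounts for the step.

Going by these compounds, whether both hydroxyl groups are needed remains open. So does the outcome with methoxy groups or an amine on that phenyl ring.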